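Adding an Amino Group to a Rearranged Core

This account rests on a few compounds, and the source may have more. Where it says the series, first, only, none or still open, it means among the compounds named here.

Compound 1 `ClCc1ccc(Cn2cnc3c(Cl)ncnc32)cc1` was tested in a functional assay on RPMI-8226 cells (Homo sapiens) for cytotoxicity, read by sulforhodamine B assay, with a stated time of 48 h (on this read-out higher numbers stand for weaker inhibition of growth and lower numbers for stronger inhibition of growth), where compound 1 gave 2130 nM. Compound 2 `Nc1nc(Cl)c2ncn(Cc3ccc(CCl)cc3)c2n1` differs from compound 1 in one place, (amino in place of hydrogen on an aromatic carbon), and in this assay compound 2 gave 3800 nM. That change produced a 1.8-fold higher number from compound 1 to compound 2 (0.25 log units; within the scatter). Compound 3 `ClCc1ccccc1Cn1cnc2c(Cl)ncnc21` is built from the same atoms as compound 1, joined differently; the difference between the two cores is not broken down here. In this assay compound 3 gave 14100 nM, the highest of the three measured numbers, and its gaps to compound 1 and to compound 2 both lie beyond the scatter.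

Compound 4 `Nc1nc(Cl)c2ncn(Cc3ccccc3CCl)c2n1` has not yet been measured. It stands to compound 3 as compound 2 stands to compound 1: amino in place of hydrogen on an aromatic carbon. The place of the change is described in the same words for both pairs, so this is the same change made on a second core. Because a 1.8-fold higher number from compound 1 to compound 2 (0.25 log units; within the scatter) stayed within the scatter, the step expected for compound 4 in this assay is of similar size, a 1.6-fold higher number from compound 3 to compound 4 (0.19 log units; within the scatter). On that basis compound 4 is expected to give about 22000 nM, with an estimated range from 9000 nM to 55000 nM. This rests on a single earlier instance of the change; how the change behaves on the core of compound 3 has not been observed.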

Compound 4, concentration for 50% growth inhibition: 11200 nM
For compound 4 the middle estimate is 2.0-fold (0.29 log units) above the measured one, within the range that was stated.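

In this assay, amino in place of hydrogen on an aromatic carbon of the core of compound 3 gave a 1.3-fold lower number from compound 3 to compound 4 (0.10 log units; within the scatter). Set beside the same change on the core of compound 1, the two steps do not differ by more than repeated measurements would allow: the same change on two cores in this assay, a 1.8-fold higher number (0.25 log units; within the scatter) from compound 1 to compound 2 and a 1.3-fold lower number (0.10 log units; within the scatter) from compound 3 to compound 4, 2.2-fold (0.35 log units) apart, within the scatter of two such steps. In this series, then, the change carries from one core to the other as a step that cannot be told from the scatter on either core, but two pairs do not show that the amino group has any real effect on growth inhibition in either direction, nor that a third core would behave alike.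

The compounds shown have only hydrogen or amino at this place, so it remains open whether a methylamino group, a hydroxyl group or a longer chain ending in an amine would also leave the number within the scatter on these two cores. As far as these compounds go, it also remains open whether the amino step would stay this small if a methoxy group stood in place of the chloro group on the same ring.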